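Shortening the propyl chain in a weakly active series

This account rests on a few compounds, and the source may have more. Where it says the series, first, only, none or still open, it means among the compounds named here.

In a functional assay on A549 cells (Homo sapiens) for antiproliferative activity, read by CCK-8 assay, with a stated time of 72 h (a lower number here means a stronger inhibitor of growth, a higher number a weaker inhibitor of growth), compound 1 (`CCC1C(=O)N(C)c2cnc(-n3ccc4cc(C(=O)NC)ccc43)nc2N1c1ccn(C)n1`), which has a methyl on the amide-type nitrogen, gives 43100 nM. For the measured compounds named here, this is the only number so far. Compound 2 (`CCC1C(=O)N(C)c2cnc(-n3ccc4cc(F)ccc43)nc2N1c1ccn(C)n1`), the fluoro analogue, gives "not active" (no number reported). Compound 3 (`CCCNC(=O)c1ccc2c(ccn2-c2ncc3c(n2)N(c2ccn(C)n2)C(CC)C(=O)N3C)c1`), which has a propyl chain on the same nitrogen, gives "not active" (no number reported). It therefore has no single number, and compound 2 is the only other entry in that position.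

Compound 4 (`CCNC(=O)c1ccc2c(ccn2-c2ncc3c(n2)N(c2ccn(C)n2)C(CC)C(=O)N3C)c1`) is reached from compound 3 by one change: hydrogen in place of methyl on a saturated chain carbon, two bonds along the chain from an amide-type nitrogen. This places hydrogen in place of methyl on a saturated chain carbon, two bonds along the chain from an amide-type nitrogen, so propyl becomes ethyl. The ethyl chain is intermediate in length between the methyl of compound 1 and the propyl of compound 3. Without a number for compound 3, the step cannot be sized. A small move in this assay is expected, if any, towards stronger growth inhibition, ending near the level of compound 1 at 43100 nM. For compound 4 the estimated value is 50000 nM, with an expected range of 20000 nM to 100000 nM. A report without any number remains about as likely as a measured value.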

Compound 4, concentration for 50% growth inhibition: 21700 nM
For compound 4 the middle estimate is 2.3-fold (0.36 log units) above the measured one, within the range that was stated.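

In this assay, for the compounds shown here, compound 4, with its ethyl chain, gives 21700 nM, while compound 3, with its propyl chain, carries no number, so the step between them cannot be read and the pair shows only that one chain length has a measured value and the other does not. Against the methyl of compound 1, the step is a 2.0-fold lower number from compound 1 to compound 4 (0.30 log units; within the scatter), so this assay does not separate methyl from ethyl on this amide-type nitrogen, and the earlier compounds offered no such comparison at this position. Going by these compounds alone, no independent evidence bears on this result, and the series so far offers only these read-outs.

Going by these compounds, whether the "not active" report for compound 3 marks a true edge at propyl, or whether the series simply sits too close to the limit of what this read-out resolves, stays open. Also open, on these data alone, is what the same nitrogen would give with only the amide hydrogen, or with a cyclopropyl, a hydroxyethyl or an aminoethyl group in place of the ethyl chain.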